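A few compounds are considered here, and "the series" means these few. Any claim that something is new, unique, unknown or untested is made for them only; others in the source may bear on it.

Measured compounds:
- compound 1, `O=c1ccn([C@H]2S[C@@H](CO)C=C2F)c(=O)[nH]1`: > 100000 nM
- compound 2, `Nc1ccn([C@H]2S[C@@H](CO)C=C2F)c(=O)n1`: > 100000 nM

In a functional assay on CCRF-CEM cells (Homo sapiens) (a lower number here means a stronger inhibitor, a higher number a weaker inhibitor), compound 1 gives > 100000 nM, which is a limit of the assay and not a number. Compound 2 likewise gives > 100000 nM, again a limit. Both values shown sit at the limit of > 100000 nM in this assay, at which 2 of the 2 values shown sit, so compound 1 stands nowhere in a ranked sense: nothing measured in the series has yet given a number. Compound 3, `Cc1cn([C@H]2S[C@@H](CO)C=C2F)c(=O)[nH]c1=O`, differs from compound 1 by methyl in place of hydrogen on an aromatic carbon. For the measured compounds named here, no step between measured compounds is available to scale this change, and the one comparison on hand, compound 1 against compound 2, shows only two limits. For the step from compound 1 to compound 3 the expectation is therefore no shift beyond the scatter that could be read from the data, and a step that the limit leaves unreadable from compound 1 to compound 3 is the estimated step. Compound 3 is expected to come out at 150000 nM, in the range 50000 nM to 500000 nM, most likely again only as a limit.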

Compound 3, half-maximal inhibitory concentration: > 100000 nM
Compound 3 ended at the assay's limit; the forecaster's own chance of this, stated with the estimate: 85%; the middle value does not contradict the limit.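

In this assay compound 3 gives > 100000 nM, a limit of the assay and not a number. For the compounds shown here, no step from compound 1 to compound 3 can be read, and the series stands thus: the limit of > 100000 nM in this assay, at which 3 of the 3 values shown sit. The compounds shown leave open whether methyl in place of hydrogen on an aromatic carbon changes inhibition at all, and how strongly any of them inhibits.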